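Swapping one fluoro for hydrogen in a stable compound

The compounds below may be only part of what the source reports. "The series", "measured", "known", "first", "only" and "open" are said of these compounds alone.

In an ADME assay on microsomes from liver (Mus musculus) for metabolic stability, with a stated time of 10 min, tested at 0.5 uM (a lower number here means that less of the compound is left, a higher number that more of the compound is left), compound 2 (`Cn1cc(-c2ccc(C(F)(F)F)cc2)c2cc(F)c(C(=O)NS(C)(=O)=O)cc21`) gives 95% and sits within the usual scatter of compound 1 (`Cn1cc(-c2ccc(C(F)(F)F)cc2)c2ccc(C(=O)NS(=O)(=O)C3CC3)cc21`), which gives 87% in the same test. Compound 3 (`Cn1cc(-c2ccc(C(F)(F)F)cc2)c2ccc(C(=O)NS(C)(=O)=O)cc21`) carries hydrogen in place of fluoro on an aromatic carbon, ortho to a (methylsulfonyl)carbamoyl group (hydrogen in place of fluoro on an aromatic carbon). Within the data shown here, no measured pair shows this swap alone, so no step beyond the scatter is expected in this assay here. The estimated change is a number 5 percentage points lower from compound 2 to compound 3 (within the scatter) overall. Compound 3 is expected to give 90%, with an estimated range of 78% to 98% for repeated measurements.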

Compound 3, percent of the compound remaining: 54%
For compound 3 the middle estimate is 36 percentage points above the measured one; the whole stated range lies above it.
By their numbers in this assay, from the lowest: compound 3; then compounds 1 and 2 (each within the scatter of the next).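

Hydrogen in place of fluoro, ortho to a (methylsulfonyl)carbamoyl group, gives a number 41 percentage points lower from compound 2 to compound 3 (beyond the scatter) in this assay, so what sits on this aromatic carbon counts in this test. Methyl in place of cyclopropyl on a sulfonyl sulfur gives a number 33 percentage points lower from compound 1 to compound 3 (beyond the scatter) as well, so a single change at either place separates compound 3 from the others. Nothing available here gives a reason for either step.

On these data alone, whether chloro or methoxy on that aromatic carbon would behave like fluoro or like hydrogen stays open. So does whether ethyl on the sulfonyl sulfur would behave like methyl or like cyclopropyl.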